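Giving up the tetrazole: expected stability of compound 4

The source may hold more compounds than are shown below. What is called first, only, known or untested is meant among the compounds shown, and "the series" means these compounds.

In an ADME assay on microsomes from liver (Mus musculus) for metabolic stability (on this read-out higher numbers stand for a longer-lived compound and lower numbers for a shorter-lived compound), compound 3 `CC(C)C(Cc1nnn[nH]1)c1ccc(-c2ccc3cccc(F)c3c2)[nH]c1=O` at 0.853 h stands highest of the three measured compounds. Compound 2 `CC(C)C(c1ncco1)c1ccc(-c2ccc3cccc(F)c3c2)[nH]c1=O` gives 0.08 h on the same read-out. Compound 1 `CC(C)C(Cc1ncc[nH]1)c1ccc(-c2ccc3cccc(F)c3c2)[nH]c1=O` shows < 0.0667 h as a limit of the assay and not a number. Compound 4 `Cc1c[nH]c(C(c2ccc(-c3ccc4cccc(F)c4c3)[nH]c2=O)C(C)C)n1` has 4-methyl-1H-imidazol-2-yl in place of (1H-tetrazol-5-yl)methyl on a saturated chain carbon bound to an aromatic carbon and a saturated chain carbon and is still unmeasured. Among the compounds with values here, two measured steps bear on this: an 11-fold higher number from compound 2 to compound 3 (1.03 log units; beyond the scatter) and an at least 12-fold higher number from compound 1 to compound 3 (1.10 log units; beyond the scatter) are both large, and each brings in the 1H-tetrazol-5-yl group that compound 4 lacks. Without that group, an at least 1.1-fold higher number from compound 1 to compound 2 (0.07 log units; that floor lies within the scatter) shows no clear separation. A large drop is therefore expected, namely an 11-fold lower number from compound 3 to compound 4 (1.03 log units; beyond the scatter) as estimated. Compound 4 is estimated at 0.08 h with 0.04 h to 0.25 h as the expected range.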

Compound 4, half-life: < 0.0667 h
Compound 4 was reported as a limit; the forecaster's own chance of this, stated with the estimate: 45%; at least 1.1-fold (0.07 log units) between middle value and limit.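

In this assay, 4-methyl-1H-imidazol-2-yl on this saturated chain carbon brings an at least 12-fold lower number from compound 3 to compound 4 (1.10 log units; beyond the scatter), so this imidazole, carrying its methyl group and set directly on the chain carbon, does not keep the half-life of the tetrazole. Set against 1,3-oxazol-2-yl in the same place, it gives an at least 1.1-fold lower number from compound 2 to compound 4 (0.07 log units; that floor lies within the scatter), which leaves the two unseparated. Compound 4 stands at a limit and not a number, as does compound 1, so the step joining them cannot be read: the limit of < 0.0667 h in this assay, at which 2 of the 4 values shown sit.

Going by these compounds, it remains open whether 1H-tetrazol-5-yl set directly on the chain carbon would keep the half-life of compound 3. On these data alone, it is equally open whether a carboxylic acid in that place would.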